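A few compounds are considered here, and "the series" means these few. Any claim that something is new, unique, unknown or untested is made for them only; others in the source may bear on it.

Of the compounds shown here, three have been tested in a functional assay on CHO-K1 cells for antagonist activity at transient receptor potential cation channel subfamily V member 1 (Homo sapiens), read by FLIPR; a lower number here means a stronger inhibitor, a higher number a weaker inhibitor. Compound 1 `CC(C(=O)NCc1ccc(C(F)(F)F)nc1NCC1CCN(C(=O)OC(C)(C)C)CC1)c1ccc(NS(C)(=O)=O)c(F)c1` gives 19.3 nM in this assay, and compound 3 `C[C@H](C(=O)NCc1ccc(C(F)(F)F)nc1N1CC[C@H](N(C)C)C1)c1ccc(NS(C)(=O)=O)c(F)c1` gives 103 nM in this assay. Compound 2 `CC(C(=O)NCc1ccc(C(F)(F)F)nc1NCc1cccnc1)c1ccc(NS(C)(=O)=O)c(F)c1` stands apart from both: in this assay compound 2 was reported as "not active" (no number reported), so no single number describes where it lies, only that it fell short of the two measured compounds.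

Compound 4 `CC(C(=O)NCc1ccc(C(F)(F)F)nc1N1CCC(c2ccccc2)CC1)c1ccc(NS(C)(=O)=O)c(F)c1` is the next compound, not yet measured in this assay. It differs from compound 2 in one place: 4-phenylpiperidin-1-yl in place of ((pyridin-3-yl)methyl)amino on an aromatic carbon. For the measured compounds named here, since compound 2 gave no number, no step between measured compounds is available to size this change, and the expectation rests on compound 1 with 19.3 nM and compound 3 with 103 nM, both carrying a saturated ring with one nitrogen at the same place. The move from compound 2 to compound 4 is expected to be a large gain, well beyond the scatter, bringing compound 4 back into the measurable range. Compound 4 is estimated at 60 nM in this assay, with a range from 12 nM to 600 nM.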

Compound 4, inhibition constant: 0.6 nM
Compound 4: the middle estimate sits 100-fold (2.00 log units) above what was measured; the measured number lies below the stated range.
By their numbers in this assay, from the lowest: compound 4; then compound 1; then compound 3.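

In this assay, for the compounds shown here, compound 2 has no number, so no step to compound 4 can be read. Nothing measured here offers an explanation for the result. The compounds shown leave open which part of the 4-phenylpiperidin-1-yl group goes with the value of compound 4.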